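Trimming the Amine Substituent: Benzyl Gives Way to Isopropyl

This account rests on a few compounds, and the source may have more. Where it says the series, first, only, none or still open, it means among the compounds named here.

Of the compounds shown here, three built on one shared core have been measured. Compound 1 `COc1ccc(CNCc2c(OC)cc(Oc3cccc(Nc4ccccc4)c3)cc2OC)cc1` gives 1910 nM in a functional assay on DLD-1 cells (Homo sapiens) for inhibition, read by MTT assay, with a stated time of 72 h; a lower number here means a stronger inhibitor, a higher number a weaker inhibitor. Compound 2 `COc1cc(Oc2cccc(Nc3ccccc3)c2)cc(OC)c1CNCc1ccccc1` gives 5220 nM in this assay, the higher of the two numbers recorded, and the step of a 2.7-fold higher number from compound 1 to compound 2 (0.44 log units; beyond the scatter) separates it from compound 1. Compound 3 `CCN1CCN(Cc2c(OC)cc(Oc3cccc(Nc4ccccc4)c3)cc2OC)CC1` reaches only the limit of > 20000 nM in this assay, so its value is a limit rather than a number; the limit of > 20000 nM in this assay, at which 1 of the 3 values shown sits, marks the boundary there.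

Compound 4 `COc1cc(Oc2cccc(Nc3ccccc3)c2)cc(OC)c1CNC(C)C` differs from compound 2 by isopropyl in place of benzyl on an amine nitrogen. Going by the values given here, two measured steps bear on this change. Shrinking the amine substituent from compound 2 to compound 3 gave an at least 3.8-fold higher number from compound 2 to compound 3 (0.58 log units; beyond the scatter), and paring the benzyl side from compound 1 to compound 2 gave a 2.7-fold higher number from compound 1 to compound 2 (0.44 log units; beyond the scatter); both moves made the number larger. A reduction from benzyl to isopropyl is therefore expected to weaken compound 4 as well, by a modest step of a 2.3-fold higher number from compound 2 to compound 4 (0.36 log units; beyond the scatter). Compound 4 is estimated at 12000 nM, with a range from 5000 nM to 30000 nM.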

Compound 4, half-maximal inhibitory concentration: > 20000 nM
Compound 4: a limit, no number (the forecaster's own chance of this, stated with the estimate: 25%); middle value at least 1.6-fold (0.22 log units) away from the limit.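

In this assay compound 4 reaches > 20000 nM, which is a limit and not a number. Isopropyl on the amine nitrogen gives an at least 3.8-fold higher number from compound 2 to compound 4 (0.58 log units; beyond the scatter), and against the 4-methoxybenzyl group it gives an at least 10-fold higher number from compound 1 to compound 4 (1.01 log units; beyond the scatter), so among these three compounds the two whose amine substituent carries a six-membered aromatic ring give numbers, while isopropyl, with no ring, does not. The step from compound 3 to compound 4 cannot be read, and the two compounds share one boundary: the limit of > 20000 nM in this assay, at which 2 of the 4 values shown sit.

As far as these compounds go, how far compound 4 lies past its limit remains open. Also open, from the compounds shown here alone, is whether the aromatic ring itself matters or only the larger substituent, a question that a cyclohexylmethyl group on the same nitrogen would address.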